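The source may hold more compounds than are shown below. What is called first, only, known or untested is meant among the compounds shown, and "the series" means these compounds.

Compound 1 `Cc1cn(C2CC(N=[N+]=[N-])C(COC(=O)OCCCCCCCCO)O2)c(=O)[nH]c1=O` carries an (8-hydroxyoctyl)oxy group on a carbonyl carbon attached to the shared core. In a functional assay on MT4 cells (Homo sapiens) for cytotoxicity (on this read-out higher numbers stand for lower toxicity in this test and lower numbers for higher toxicity in this test), compound 1 gives only a limit of the assay, > 50000 nM. Two close relatives were tested the same way. In this assay compound 2 `Cc1cn(C2CC(N=[N+]=[N-])C(COC(=O)NCCCO)O2)c(=O)[nH]c1=O` gives a limit, > 50000 nM. In this assay compound 3 `CCCCOC(=O)OCC1OC(n2cc(C)c(=O)[nH]c2=O)CC1N=[N+]=[N-]` gives a limit, > 50000 nM. The steps a step that the two limits leave unreadable from compound 1 to compound 2, a step that the two limits leave unreadable from compound 1 to compound 3 and a step that the two limits leave unreadable from compound 2 to compound 3 cannot be sized because every value sits at the limit of > 50000 nM in this assay, at which 3 of the 3 values shown sit. Compound 4 `Cc1cn(C2CC(N=[N+]=[N-])C(COC(=O)CCCN)O2)c(=O)[nH]c1=O` differs from compound 1 by 3-aminopropyl in place of (8-hydroxyoctyl)oxy on a carbonyl carbon. Among the compounds with values here, no measured step can favour or oppose this change, so compound 4 is expected to sit at the limit as well. The estimate for compound 4 is 50000 nM, within 20000 nM to 120000 nM, an expected step of a number no higher from compound 1 to compound 4 (the limit leaves the size open) of nothing beyond the scatter.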

Compound 4, half-maximal cytotoxic concentration: > 50000 nM
Compound 4: a limit, no number; the forecaster's own chance of this, stated with the estimate: 85%; the middle value sits exactly at the limit.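

Within the data shown here, compound 4, like compounds 1, 2 and 3, gives only a limit, so no step between compound 4 and any of them can be read: the limit of > 50000 nM in this assay, at which 4 of the 4 values shown sit.

The compounds shown leave open whether these groups on the carbonyl carbon differ at all in this assay from one another.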